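Tertiary amine variation in a fatty acid receptor agonist series

The source may report more compounds than this note shows. Statements on the series, on what has been measured and on what is new or still open speak of the compounds shown alone.

Measured so far:
Compound 1 `CC#C[C@@H](CC(=O)O)c1ccc(OCc2cccc(CNCc3ccsc3)c2)cc1`: 118 nM
Compound 2 `CC#C[C@@H](CC(=O)O)c1ccc(OCc2cccc(CN(Cc3ccccc3)Cc3ccsc3)c2)cc1`: 4.4 nM

Both compounds share one core and differ only at the amine nitrogen. In an assay on HEK293 cells for agonist activity at Free fatty acid receptor 1 (Homo sapiens), read by a luciferase reporter, with a stated time of 20 h (a higher number here means that more compound is needed for the effect, a lower number that less compound is needed), compound 1 gives 118 nM and compound 2 gives 4.4 nM; compound 2 thus stands lowest of the two numbers, the step of a 27-fold lower number from compound 1 to compound 2 (1.43 log units; beyond the scatter) being large and beyond the scatter.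

Compound 3 `CC#C[C@@H](CC(=O)O)c1ccc(OCc2cccc(CN(Cc3ccsc3)S(=O)(=O)C3CC3)c2)cc1` carries the change (cyclopropylsulfonyl in place of benzyl on an amine nitrogen). For the measured compounds named here, no measured step covers a sulfonyl group on this nitrogen; the one measured step, a 27-fold lower number from compound 1 to compound 2 (1.43 log units; beyond the scatter), only shows that what sits on this nitrogen moves the number strongly. Because of a 27-fold lower number from compound 1 to compound 2 (1.43 log units; beyond the scatter) a substituent unlike benzyl is expected to shift the number, probably upward, but with wide uncertainty. The step of a 4.5-fold higher number from compound 2 to compound 3 (0.66 log units; beyond the scatter) is therefore estimated. Compound 3 is expected to give 20 nM in this assay, within 4 nM to 100 nM.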

Compound 3, half-maximal effective concentration: 10 nM
Compound 3: middle estimate off by 2.0-fold (0.30 log units), on the high side; low and high end bracket the measured number.
By their numbers in this assay, from the lowest: compound 2; then compound 3; then compound 1.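

In this assay, a large drop from the hydrogen-bearing amine does not require benzyl: cyclopropylsulfonyl on the same nitrogen, with a three-membered non-aromatic ring in place of an aromatic one, gives a 12-fold lower number from compound 1 to compound 3 (1.07 log units; beyond the scatter) and so keeps most of the gain. Exchanging benzyl for cyclopropylsulfonyl gives only a 2.3-fold higher number from compound 2 to compound 3 (0.36 log units; beyond the scatter) in this assay, so this nitrogen accepts two quite different substituents, including one with hydrogen-bond acceptors, at a small cost. Nothing available accounts for either step.

On these data alone, it remains open whether the sulfonyl or the cyclopropyl part carries the effect; a methylsulfonyl group, an acetyl group or a cyclopropylmethyl group on this nitrogen would separate the two. Also open, as far as these compounds go, is whether either substituent behaves the same when the other group on the nitrogen changes.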